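Aromatic ring swap on a fused thiophene core

The source may report more compounds than this note shows. Statements on the series, on what has been measured and on what is new or still open speak of the compounds shown alone.

Measured compounds:
Compound 1 `CCn1c(NC(C)C)nc2c(C3CCNCC3)csc2c1=O` — 190 nM
Compound 2 `CCn1c(NC(C)C)nc2c(-c3cncnc3)csc2c1=O` — 7.6 nM

In an assay on cells for inhibition of high affinity 3',5'-cyclic-AMP phosphodiesterase 7A (Homo sapiens), read by scintillation counting and cAMP accumulation, with a stated time of 30 min (on this read-out lower numbers stand for stronger inhibition and higher numbers for weaker inhibition), compound 2 gives the lower of the two numbers, and the step of a 25-fold lower number from compound 1 to compound 2 (1.40 log units; beyond the scatter) shows how much the aromatic ring improved on the saturated amine ring in the same place on the shared core. Compound 3 `CCn1c(NC(C)C)nc2c(-c3ccnc(OC)c3)csc2c1=O` is the next step: 2-methoxypyridin-4-yl in place of pyrimidin-5-yl on an aromatic carbon. Among the measured compounds shown here, one six-membered aromatic ring is exchanged for another, so the only measured step, from compound 1 to compound 2, speaks to a change of a different kind and bears only loosely on this one. Since both rings are aromatic and carry the same count of acceptors, the expected step of a 1.3-fold higher number from compound 2 to compound 3 (0.12 log units; within the scatter) is small, most likely within the scatter. Compound 3 is therefore estimated at 10 nM, within a range of 3 nM to 40 nM.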

Compound 3, half-maximal inhibitory concentration in the high affinity 3',5'-cyclic-AMP phosphodiesterase 7A assay: 4.6 nM
For compound 3 the middle estimate is 2.2-fold (0.34 log units) above the measured one; the measured number falls inside the stated range.
By their numbers in the high affinity 3',5'-cyclic-AMP phosphodiesterase 7A assay, from the lowest: compounds 3 and 2 (each within the scatter of the next); then compound 1.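

In the high affinity 3',5'-cyclic-AMP phosphodiesterase 7A assay, exchanging one six-membered aromatic ring for another on this aromatic carbon gives a 1.7-fold lower number from compound 2 to compound 3 (0.22 log units; within the scatter), so the larger 2-methoxypyridin-4-yl group leaves inhibition unchanged within the scatter. The aromatic ring of compound 3 also stands far from the saturated ring of compound 1, with a 41-fold lower number from compound 1 to compound 3 (1.62 log units; beyond the scatter), which matches what compound 2 showed for the same kind of exchange. In a physicochemical assay for solubility, in phosphate buffer, at pH 6.8 (on this read-out lower numbers stand for lower solubility and higher numbers for higher solubility), compound 2 gives 18 ug/mL and compound 3 gives 2.4 ug/mL. The swap separates compound 2 and compound 3 only in the physicochemical assay, where it has a clear cost: the measured solubility of compound 2, 18 ug/mL, and of compound 3, 2.4 ug/mL, a 7.5-fold lower number (0.88 log units; beyond the scatter)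

As far as these compounds go, it remains open which part of the change carries this loss, as the ring nitrogen and the methoxy group change together in this one step. A pyridin-4-yl ring without the methoxy group, or with an amine in its place, would help to separate the two.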